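From Butyl to a Longer Chain on Compound 2

This account rests on a few compounds, and the source may have more. Where it says the series, first, only, none or still open, it means among the compounds named here.

Measured in a functional assay on brain (Rattus norvegicus, strain Wistar) for inhibition; a higher number here means a weaker inhibitor, a lower number a stronger inhibitor:
Compound 1 `CCCCc1ccc(-c2c(C)[nH]c(=O)n2C)cc1`: 10700 nM
Compound 2 `CCCCc1ccc(-c2c(C)[nH]c(=O)n2C2CCCCC2)cc1`: 27100 nM
Compound 3 `Cc1[nH]c(=O)n(C2CCCCC2)c1-c1ccc(C2CCCCC2)cc1`: 28900 nM

Compound 2 sits with compound 3 at the high end of these three numbers, and the gap between them lies within the scatter (a 1.1-fold higher number from compound 2 to compound 3 (0.03 log units; within the scatter)). Compound 1 stands apart from that pair, with a lower number (a 2.5-fold higher number from compound 1 to compound 2 (0.40 log units; beyond the scatter)).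

Compound 4 `CCCCCCCCCCCCc1ccc(-c2c(C)[nH]c(=O)n2C2CCCCC2)cc1` remains unmeasured. Its difference from compound 2 is octyl in place of hydrogen on a saturated chain carbon, four bonds along the chain from an aromatic carbon.

Within the data shown here, no measured step lengthens a chain, so the evidence is indirect. Cyclohexyl in place of butyl on an aromatic carbon, the one measured change to that group, gave a 1.1-fold higher number from compound 2 to compound 3 (0.03 log units; within the scatter) in this assay. Among the measured compounds shown here, the only step beyond the scatter, cyclohexyl in place of methyl on an aromatic nitrogen, was modest and was made elsewhere on the molecule. No step beyond the scatter is therefore expected, and the data fix no firm direction. The expected change is a 1.5-fold lower number from compound 2 to compound 4 (0.18 log units; within the scatter), though a chain of this length goes beyond anything measured. For compound 4 the estimate is 18000 nM, with an expected range of 4000 nM to 50000 nM.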

Compound 4, half-maximal inhibitory concentration: > 100000 nM
Compound 4: only a limit was reported; the forecaster's own chance of this, stated with the estimate: 10%; at least 5.5-fold (0.74 log units) between middle value and limit.
By their numbers in this assay, from the lowest: compound 1; then compounds 2 and 3 (each within the scatter of the next). At a limit, above all of these: compound 4.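

In this assay, octyl in place of hydrogen on a saturated chain carbon, four bonds along the chain from an aromatic carbon, gives an at least 3.6-fold higher number from compound 2 to compound 4 (0.56 log units; beyond the scatter). Among these compounds, this shows that the group carried on this aromatic carbon can matter: the earlier change there, cyclohexyl in place of butyl, gave only a 1.1-fold higher number from compound 2 to compound 3 (0.03 log units; within the scatter), and the one earlier step beyond the scatter, a 2.5-fold higher number from compound 1 to compound 2 (0.40 log units; beyond the scatter), was made on an aromatic nitrogen. Lengthening the butyl chain by octyl therefore makes compound 4 a weaker inhibitor than compound 2, although compound 4 is reported only as a limit and not as a number, so the step has a lower bound but no known size: the limit of > 100000 nM in this assay, at which 1 of the 4 values shown sits.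

The compounds shown leave open how the number changes along the way from the butyl of compound 2 to the chain of compound 4, and a hexyl chain would fall in that gap. They also leave open whether a chain of similar length ending in an amine or a carboxylic acid would behave as the plain chain does.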